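The compounds below may be only part of what the source reports. "The series", "measured", "known", "first", "only" and "open" are said of these compounds alone.

Measured compounds:
compound 1 `CCCCCCCCCCCC(=O)OC[C@H](CSC[C@@H](N)C(=O)NC1(CO)CC1)OC(=O)CCCCCCCCCCC` — an assay on HEK293 cells for agonist activity at Toll-like receptor 2 (Homo sapiens); a higher number here means that more compound is needed for the effect, a lower number that less compound is needed: 265 nM
compound 2 `CCCCCCCCCCCC(=O)OC[C@H](CSC[C@@H](N)C(=O)N[C@@H](CC)COCC(=O)O)OC(=O)CCCCCCCCCCC` — this assay: 6500 nM

Compound 2 carries the highest of the two numbers; the nearest is compound 1, separated by a 25-fold higher number from compound 1 to compound 2 (1.39 log units; beyond the scatter). Compound 3 `CCCCCCCCCCCC(=O)OC[C@H](CSC[C@@H](N)C(=O)NCCCCCC(=O)O)OC(=O)CCCCCCCCCCC` differs from compound 2 by 5-carboxypentyl in place of 1-((carboxymethoxy)methyl)propyl on an amide-type nitrogen. Within the data shown here, only one measured step touches this position, a 25-fold higher number from compound 1 to compound 2 (1.39 log units; beyond the scatter), and it was large, so another exchange on the amide-type nitrogen is expected to move the number beyond the scatter; with a single step the direction is uncertain, and a partial return toward compound 1 is assumed. Compound 3 is estimated at 2000 nM, within 400 nM to 10000 nM. The expected step is a 3.3-fold lower number from compound 2 to compound 3 (0.51 log units; beyond the scatter).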

Compound 3, half-maximal effective concentration: 108 nM
Estimate against measurement, compound 3: 19-fold (1.27 log units) above; the whole stated range lies above it.
By their numbers in this assay, from the lowest: compound 3; then compound 1; then compound 2.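

In this assay, a carboxylic acid at the end of the group on the amide-type nitrogen does not by itself set a high number: both groups in the exchange carry one, yet the step reads (a 60-fold lower number from compound 2 to compound 3 (1.78 log units; beyond the scatter)). Against 1-(hydroxymethyl)cyclopropyl, 5-carboxypentyl gives a modest step (a 2.5-fold lower number from compound 1 to compound 3 (0.39 log units; beyond the scatter)). No data on hand account for either step.

The exchange removes the branch, the ether oxygen and the defined stereocentre together, so their shares remain unseparated. Going by these compounds, how a longer chain or an amine at the chain end would read in this assay also remains open.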